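Two Hydroxyls in Place of a Fluorine: Compound 4 Ahead

A few compounds are considered here, and "the series" means these few. Any claim that something is new, unique, unknown or untested is made for them only; others in the source may bear on it.

The measured compounds so far:
Compound 1 `O=C(N/N=C/c1ccc(F)cc1)Nc1cc2c(Nc3ccc(F)c(Cl)c3)ncnc2cc1O[C@H]1CCOC1` gives 28200 nM in a functional assay on MCF7 cells (Homo sapiens) for cytotoxicity, read by MTT assay, with a stated time of 72 h; a higher number here means a weaker inhibitor, a lower number a stronger inhibitor.
Compound 2 `O=C(N/N=C/c1ccc(F)cc1Cl)Nc1cc2c(Nc3ccc(F)c(Cl)c3)ncnc2cc1O[C@H]1CCOC1` gives 32200 nM in this assay.
Compound 3 `COc1cc2ncnc(Nc3ccc(F)c(Cl)c3)c2cc1NC(=O)N/N=C/c1ccc(F)cc1` gives 35100 nM in this assay.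

All three numbers sit close together. Compound 3 has the highest of the three, but its gap to compound 2 and to compound 1 is within the scatter, so no order among them can be claimed. The two measured steps are small: a 1.1-fold higher number from compound 1 to compound 2 (0.06 log units; within the scatter) and a 1.2-fold higher number from compound 1 to compound 3 (0.10 log units; within the scatter), each within the scatter.

Compound 4 `COc1cc2ncnc(Nc3ccc(F)c(Cl)c3)c2cc1NC(=O)N/N=C/c1ccc(O)cc1O` has not yet been tested in this assay. It differs from compound 3 in one place: 2,4-dihydroxyphenyl in place of 4-fluorophenyl on a carbon with a double bond to nitrogen. Going by the values given here, of the measured steps, only the one from compound 1 to compound 2 touches the same ring, the one on a carbon with a double bond to nitrogen, and that step was within the scatter. Among the compounds with values here, no measured pair shows what hydroxyl groups on this ring do. On these data alone, on this basis the step of a 1.2-fold lower number from compound 3 to compound 4 (0.07 log units; within the scatter) is expected to stay within the scatter, with wide uncertainty because the change is untested. Compound 4 is therefore estimated at 30000 nM, within a range of 9000 nM to 100000 nM.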

Compound 4, half-maximal inhibitory concentration: 36200 nM
Compound 4: the middle estimate sits 1.2-fold (0.08 log units) below what was measured, within the range that was stated.
By their numbers in this assay, from the lowest: compounds 1, 2, 3 and 4 (each within the scatter of the next).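

Going by these compounds alone, the exchange of 4-fluorophenyl for 2,4-dihydroxyphenyl on the carbon with a double bond to nitrogen comes to a 1.0-fold higher number from compound 3 to compound 4 (0.01 log units; within the scatter) in this assay and is the first measured step in which the fluorine on this ring is given up. Within the data shown here, the only earlier step on this ring, a 1.1-fold higher number from compound 1 to compound 2 (0.06 log units; within the scatter), added a chloro and kept the fluorine, whereas the new step brings in a group with 2 hydrogen-bond donors and 2 hydrogen-bond acceptors in place of one with 0 of each, and even this exchange stays within the scatter. No measurement in hand speaks to the reason for this result.

The compounds shown do not tell whether 2,4-dihydroxyphenyl gives a like result with the oxolan-3-yl group of compound 1 in place of the methyl of compound 4. They also leave open whether a single hydroxyl, an amine or a carboxylic acid on this ring, or a longer chain in place of the ring itself, would produce a step beyond the scatter.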